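Replacing a phenyl with isopropoxycarbonyl: compound 2 to compound 4

The source may hold more compounds than are shown below. What is called first, only, known or untested is meant among the compounds shown, and "the series" means these compounds.

- Compound 1 `N#Cc1ccc(NCc2cncn2Cc2ccc(-c3ccccc3)cc2N)cc1-c1ccccc1` gives > 1000 nM (a limit)
- Compound 2 `c1ccc(-c2ccc(Cn3cncc3CNc3ccc(-c4ccccc4)c(-c4ccccc4)c3)cc2)cc1` gives > 10000 nM (a limit)
- Compound 3 `COC(=O)c1ccc(NCc2cncn2Cc2ccccc2Br)cc1-c1ccccc1` gives 10000 nM

Among the compounds with values here, all three values come from a toxicity assay on NIH3T3 cells (Mus musculus) for cytotoxicity, read by resazurin assay (a higher number here means that more compound is needed for the effect, a lower number that less compound is needed), and no measured step links these compounds. Compound 2 stands at > 10000 nM and this is a limit, not a number. Compound 4 `CC(C)OC(=O)c1ccc(NCc2cncn2Cc2ccc(-c3ccccc3)cc2)cc1-c1ccccc1` carries isopropoxycarbonyl in place of phenyl on an aromatic carbon and is still to be measured. The expectation leans on compound 3 with its 10000 nM as a number, since it has a methoxycarbonyl group at that place, though it differs elsewhere too. The expected change a number no higher from compound 2 to compound 4 (the limit leaves the size open) stays within the scatter, with no direction foreseen. For compound 4 the estimate is 10000 nM with 3000 nM to 30000 nM as its expected range.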

Compound 4, half-maximal effective concentration: > 10000 nM
Compound 4 gave a limit, no number; the forecaster's own chance of this, stated with the estimate: 45%; the middle value lies on the limit itself.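

The step between compound 2 and compound 4 cannot be read: both values are limits, not numbers. The compounds shown leave open whether isopropoxycarbonyl in place of phenyl on an aromatic carbon changes the concentration needed for the effect at all.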